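Compound 4 and a limit in the series

The source may hold more compounds than are shown below. What is called first, only, known or untested is meant among the compounds shown, and "the series" means these compounds.

Values in a functional assay on HL-60 cells (Homo sapiens) for antiproliferative activity, read by sulforhodamine B assay, with a stated time of 72 h (on this read-out lower numbers stand for stronger inhibition and higher numbers for weaker inhibition), follow

Compound 1 `FC(F)(F)c1ccccc1NC(=S)N/N=C/c1ccc2ccccc2n1` gives 13200 nM
Compound 2 `Fc1ccccc1NC(=S)N/N=C/c1ccc2ccccc2n1` gives > 100000 nM
Compound 3 `NC(=S)N/N=C/c1cc2ccccc2s1` gives > 100000 nM

Compound 2 has no exact value, since its > 100000 nM is a limit of this assay and not a number. The entry for compound 3 is likewise a limit, at > 100000 nM. Together, compound 2 and compound 3 account for (the limit of > 100000 nM in this assay, at which 2 of the 3 values shown sit).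

The next step leads from compound 2 to compound 4 `Cc1ccc(NC(=S)N/N=C/c2ccc3ccccc3n2)cc1`. The change is 4-methylphenyl in place of 2-fluorophenyl on an amide-type nitrogen.

Among the compounds with values here, only one measured step bears on this change, and it also alters the aromatic group on the shared core. That step is an at least 7.5-fold higher number from compound 1 to compound 2 (0.87 log units; beyond the scatter), with fluoro in place of trifluoromethyl on an aromatic carbon. Compound 1 gives 13200 nM, which shows that a number can be reached with this core. Within the data shown here, no measured step tests the 4-methylphenyl group itself, so the expectation is loose: a modest move toward stronger inhibition, with a real chance of remaining at the limit.

The expected step is an at least 2.8-fold lower number from compound 2 to compound 4 (0.45 log units; beyond the scatter). For compound 4 the estimated value is 35000 nM, with an expected range from 9000 nM to 100000 nM.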

Compound 4, half-maximal inhibitory concentration: 78300 nM
Beside the measured number, compound 4's estimate is 2.2-fold (0.35 log units) below it, within the range that was stated.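

In this assay, within the data shown here, compound 4 gives 78300 nM, so a 4-methylphenyl group on the amide-type nitrogen, whose other neighbour is the thiocarbonyl carbon, yields a readable number, and on the shared core compound 1 is no longer the only compound that does. Putting 4-methylphenyl in place of 2-fluorophenyl gives an at least 1.2-fold lower number from compound 2 to compound 4 (0.10 log units; that floor lies within the scatter), and that floor is all the step can state. The true size of the step cannot be read because compound 2 carries a limit and not a number: the limit of > 100000 nM in this assay, at which 2 of the 4 values shown sit.

The change replaces fluoro with methyl and also moves the substituent from the 2 place to the 4 place on the phenyl ring, so the compounds shown cannot tell these two differences apart. As far as these compounds go, what a 2-methylphenyl, 4-fluorophenyl, 4-methoxyphenyl or 4-trifluoromethylphenyl group would give on this nitrogen stays open, and those groups would be needed to separate the kind of substituent from its place on the ring.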